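The source may report more compounds than this note shows. Statements on the series, on what has been measured and on what is new or still open speak of the compounds shown alone.

Three amides were tested in an assay for inhibition of HSP60/HSP10 (Homo sapiens), with a stated time of 60 min; a higher number here means a weaker inhibitor, a lower number a stronger inhibitor. Compound 1 `COc1c(Br)cccc1C(=O)Nc1ccccc1` gives only a limit in this assay, > 100000 nM. Compound 2 `COc1ccccc1C(=O)Nc1cccc(Cl)c1` also returns a limit, > 100000 nM. Compound 3 `COc1c(Br)cc(Br)cc1C(=O)Nc1cccc(Cl)c1`, which carries two bromo groups, likewise reaches only the limit, > 100000 nM. Within the data shown here, compound 3 therefore stands where all three measured compounds stand, namely at the limit of > 100000 nM in this assay, at which 3 of the 3 values shown sit, and no step between them can be sized. Compound 4 `COc1c(Br)cccc1C(=O)Nc1cccc(Cl)c1` has not been measured; it differs from compound 3 by hydrogen in place of bromo on an aromatic carbon. With every measured compound at the limit, the removal of one bromo gives no footing for expecting a change beyond the scatter, and the step is estimated as a step that the limit leaves unreadable from compound 3 to compound 4. Compound 4 is thus expected to give about 150000 nM, within 50000 nM to 500000 nM, most likely reported again as a limit.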

Compound 4, half-maximal inhibitory concentration: > 100000 nM
Compound 4: no number, only a limit; the forecaster's own chance of this, stated with the estimate: 85%; the middle value lies beyond the limit too.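

Among these compounds, compound 4, like compound 1, compound 2 and compound 3, reaches only a limit in this assay and so no step among them can be read: the limit of > 100000 nM in this assay, at which 4 of the 4 values shown sit. The compounds shown leave open which structural change, if any, would give a measurable value in this assay.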